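Capping a hydroxy group with methyl

This account rests on a few compounds, and the source may have more. Where it says the series, first, only, none or still open, it means among the compounds named here.

Measured so far in a physicochemical assay for lipophilicity, using the shake flask method; a lower number here means a more polar compound, a higher number a more lipophilic compound:
compound 1 `CC(C)Oc1cc(Oc2cnc(C(=O)N(C)C)nc2)cc(-c2nccc(=O)[nH]2)c1`: 0.97
compound 2 `C[C@@H](CO)Oc1cc(Oc2cnc(C(=O)N(C)C)nc2)cc(-c2nccc(=O)[nH]2)c1`: -0.02

Compound 2 holds the lower number of the two. Compound 3 `COC[C@H](C)Oc1cc(Oc2cnc(C(=O)N(C)C)nc2)cc(-c2nccc(=O)[nH]2)c1` is not yet measured and turns hydroxy to methoxy, with methyl in place of hydrogen on an oxygen on a saturated carbon. Within the data shown here, one measured step bears on this chain: a number 0.99 log units lower from compound 1 to compound 2 (beyond the scatter), when hydroxy took the place of hydrogen. Compound 3 keeps that oxygen, so only a partial return upward in this assay is expected. The expected change is a number 0.57 log units higher from compound 2 to compound 3 (beyond the scatter). For compound 3 the estimated value is 0.55, with an expected range of 0.2 to 0.9.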

Compound 3, distribution coefficient: 0.43
Compound 3: middle estimate off by 0.12 log units, on the high side; the range from low to high includes it.
By their numbers in this assay, from the lowest: compound 2; then compound 3; then compound 1.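

Capping the hydroxy group as methoxy wins back only part of the earlier fall in this assay (a number 0.45 log units higher from compound 2 to compound 3 (beyond the scatter)). The capped compound still stays lower than the plain chain (a number 0.54 log units lower from compound 1 to compound 3 (beyond the scatter)), so at this chain carbon the number depends both on the oxygen being present and on what that oxygen carries. No measurement shown gives a reason for either shift. Still open, going by these compounds, is how a longer chain on that oxygen, or an amine in its place, would compare with these three compounds.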